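Ethyl on the saturated ring carbon of compound 3

This account rests on a few compounds, and the source may have more. Where it says the series, first, only, none or still open, it means among the compounds named here.

Compound 3 `CCC(=O)N[C@@H]1CCCc2c1cncc2N1Cc2cc(Cl)ccc2C1=O` gives 5210 nM in an ADME assay on cells for inhibition of cytochrome P450 11B1, mitochondrial (Homo sapiens), read by HTRF; a higher number here means a weaker inhibitor, a lower number a stronger inhibitor. Among the measured compounds shown here, this is the highest of the three numbers so far, but the gaps to compound 1 `CCC1c2cc(Cl)ccc2C(=O)N1c1cccnc1` at 3340 nM and to compound 2 `CCC(=O)N[C@@H]1CCCc2c1cncc2N1CCc2cc(Cl)ccc2C1=O` at 3330 nM both fall within the usual scatter, so no ranking among the three is claimed. For the measured compounds named here, compound 1 and compound 3 differ in more than one place, so no single step between them is counted; their two values simply lie close together, and compound 1 carries an ethyl on its five-membered ring.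

Compound 4 `CCC(=O)N[C@@H]1CCCc2c1cncc2N1C(=O)c2ccc(Cl)cc2[C@@H]1CC` differs from compound 3 by ethyl in place of hydrogen on a saturated ring carbon. The ethyl sits on a saturated ring carbon of a five-membered non-aromatic ring with 1 nitrogen, part of a fused or bridged system of two rings. Going by the values given here, no measured step speaks directly to this change. Since compound 1 at 3340 nM and compound 3 at 5210 nM lie close together, the step of a 1.5-fold lower number from compound 3 to compound 4 (0.17 log units; within the scatter) is expected to stay within the scatter, if anything toward a lower number. Compound 4 is expected to give about 3500 nM, in the range 1500 nM to 8000 nM.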

Compound 4, half-maximal inhibitory concentration: 345 nM
Compound 4: the middle estimate sits 10-fold (1.01 log units) above what was measured, outside the stated range (below it).
By their numbers in this assay, from the lowest: compound 4; then compounds 2, 1 and 3 (each within the scatter of the next).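

In this assay, ethyl in place of hydrogen on a saturated ring carbon of the five-membered non-aromatic ring with 1 nitrogen gives a large change: a 15-fold lower number from compound 3 to compound 4 (1.18 log units; beyond the scatter). Among the compounds shown here, this is the first step to lie beyond the scatter, and it shows that this position, next to the ring nitrogen, can strongly shift the number, with the change here toward stronger inhibition. Nothing measured here explains the size of this step.

The compounds shown leave open how the number depends on the group at this carbon, for example whether methyl, a longer chain such as propyl, or an amine would give a similar step. Also open, from the compounds shown here alone, are the role of the opposite configuration at this carbon and whether ethyl gives a step of this size on other cores.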